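The source may hold more compounds than are shown below. What is called first, only, known or untested is meant among the compounds shown, and "the series" means these compounds.

Measured so far:
Compound 1 `N#Cc1c(-c2ccccc2)c(C#N)c(=O)n(/N=C/c2cn(-c3ccccc3)nc2-c2ccccc2)c1N` gives > 200 ug/mL in an ADME assay on HeLa cells (Homo sapiens) for cytotoxicity, read by MTT assay (a higher number here means a weaker inhibitor, a lower number a stronger inhibitor), which is a limit of the assay.
Compound 2 `N#Cc1c(-c2cccc(Cl)c2)c(C#N)c(=O)n(/N=C/c2cn(-c3ccccc3)nc2-c2ccccc2)c1N` gives > 200 ug/mL in this assay, again a limit.

Compound 1 therefore stands only at a limit in this assay. Among the measured compounds shown here, the single measured step, a step that the two limits leave unreadable from compound 1 to compound 2, cannot be read because of the limit of > 200 ug/mL in this assay, at which 2 of the 2 values shown sit. Compound 3 `N#Cc1c(-c2ccc(Br)cc2)c(C#N)c(=O)n(/N=C/c2cn(-c3ccccc3)nc2-c2ccccc2)c1N` differs from compound 1 by bromo in place of hydrogen on an aromatic carbon. No readable step bears on this change, so no step beyond the scatter is expected in this assay. Compound 3 is expected at 200 ug/mL, within 120 ug/mL to 400 ug/mL. The step expected is a number no higher from compound 1 to compound 3 (the limit leaves the size open).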

Compound 3, half-maximal inhibitory concentration: > 200 ug/mL
Compound 3: a limit, no number (the forecaster's own chance of this, stated with the estimate: 85%); the middle value lies on the limit itself.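

No step can be read among compound 1, compound 2 and compound 3 in this assay, because all three stand at one limit: the limit of > 200 ug/mL in this assay, at which 3 of the 3 values shown sit.

The compounds shown leave open whether chloro or bromo in place of hydrogen changes the read-out at all.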